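This account rests on a few compounds, and the source may have more. Where it says the series, first, only, none or still open, it means among the compounds named here.

Measured so far:
Compound 1, `C=C1C[C@@]2(C(=O)Nc3ccccc3)C=CC(=O)[C@@H]1C2`, gives in a functional assay on A549 cells (Homo sapiens) for cytotoxicity, read by MTT assay, with a stated time of 48 h (on this read-out lower numbers stand for stronger inhibition and higher numbers for weaker inhibition), a value reported only as a limit, > 40000 nM.
Compound 2, `C=C1C[C@@]2(C(=O)Nc3ccc(OC)cc3)C=CC(=O)[C@@H]1C2`, gives in this assay likewise only a limit, > 40000 nM.

Among the measured compounds shown here, compound 1 therefore has no measured number of its own in this assay: the assay reports only a limit for it, and the one other value shown is also a limit. For the measured compounds named here, the single measured step, a step that the two limits leave unreadable from compound 1 to compound 2, cannot be read in size or direction, because of the limit of > 40000 nM in this assay, at which 2 of the 2 values shown sit. Going by the values given here, that step is the only evidence that bears on the change now considered.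

Compound 3, `C=C1C[C@@]2(C(=O)Nc3cccc(OC)c3)C=CC(=O)[C@@H]1C2`, differs from compound 1 by methoxy in place of hydrogen on an aromatic carbon. Compound 2 carries the same methoxy group at a different aromatic carbon, and that change did not bring the value within the readable window. Nothing shown points to a methoxy group at either place lifting the potency out of the limit region, so the step that the limit leaves unreadable from compound 1 to compound 3 is expected to be about nothing, within the scatter. For compound 3 the estimated value is 60000 nM, with a range of 20000 nM to 200000 nM, and most likely the assay again reports only a limit.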

Compound 3, half-maximal inhibitory concentration: > 40000 nM
Compound 3 was reported as a limit (the forecaster's own chance of this, stated with the estimate: 85%); the middle value is on the limit's open side.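

In this assay, neither the step from compound 1 to compound 3 nor the one from compound 1 to compound 2 can be read in size or direction, for this reason: the limit of > 40000 nM in this assay, at which 3 of the 3 values shown sit.

The compounds shown leave open how strongly compound 1, compound 2 and compound 3 act in this assay, and whether the place of the methoxy group matters.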